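Adding a 1-methylimidazolyl Group to a Tetrazole Biphenyl Core

This account rests on a few compounds, and the source may have more. Where it says the series, first, only, none or still open, it means among the compounds named here.

Measured so far:
compound 1, `CCCCN(c1nc2ccccc2o1)[C@H](C)c1ccc(-c2ccccc2-c2nnn[nH]2)cc1`, 0.000713
compound 2, `CCCCN(c1nc2c(C(=O)O)cccc2o1)[C@H](C)c1ccc(-c2cc(Cl)ccc2-c2nc(=O)o[nH]2)cc1`, 0.000135

Of the compounds shown here, two have been measured in an ADME assay on the whole organism (plasma, Macaca fascicularis) for protein binding, read by LC-MS, using equilibrium dialysis and cassette dosing, with a stated time of 24 h, at a dose of 1 mg/kg by the oral route; a lower number here means a smaller unbound share, a higher number a larger unbound share of the compound. Compound 1 gives 0.000713, the higher of the two numbers. Among the compounds with values here, compound 2 gives 0.000135, and the gap between these two values is beyond the usual scatter; no single-point step is counted between them, since they differ in several places at once.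

Compound 3, `CCCCN(c1nc2c(-c3nccn3C)cccc2o1)[C@H](C)c1ccc(-c2ccccc2-c2nnn[nH]2)cc1`, has not yet been measured in this assay. It differs from compound 1 in one place: 1-methyl-1H-imidazol-2-yl in place of hydrogen on an aromatic carbon. Within the data shown here, no measured pair in this set shows this change, so there is no counted step to lean on. On the numbers available, the account expects a modest move downward from compound 1 to compound 3, one that may well stay within the scatter of repeated measurements; the expected step is a 1.4-fold lower number from compound 1 to compound 3 (0.15 log units; within the scatter). Compound 3 is therefore estimated to give an unbound fraction of 0.0005 in this assay, with a plausible range from 0.00015 to 0.0015, and the result is awaited.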

Compound 3, unbound fraction: 0.00299
Compound 3: the middle estimate sits 6.0-fold (0.78 log units) below what was measured, outside the stated range (above it).
By their numbers in this assay, from the lowest: compound 2; then compound 1; then compound 3.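

In this assay, 1-methyl-1H-imidazol-2-yl in place of hydrogen on an aromatic carbon, ortho to a fused ring, gives a 4.2-fold higher number from compound 1 to compound 3 (0.62 log units; beyond the scatter), and so a larger unbound share. This is the only single-place change among the compounds shown, and it gives the first direct reading for this position: with the rest of compound 1 unchanged, a group of six heavy atoms at this carbon raises the number beyond the scatter rather than lowering it or leaving it within the scatter. The data shown hold nothing that could explain why the unbound share rises at this position.

From the compounds shown here alone, with one group tested alone at this carbon, it remains open whether the step belongs to the 1-methyl-1H-imidazol-2-yl group in particular or would also appear with a methoxy group, an aminomethyl group, a pyridine ring or the imidazole without its methyl. Going by these compounds, it also remains open whether the same replacement would move the number in the same direction at the other aromatic carbons of this ring, or on a core carrying other changes.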